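Notes on removing trifluoromethyl from compound 2

The compounds below may be only part of what the source reports. "The series", "measured", "known", "first", "only" and "open" are said of these compounds alone.

Values in an in vitro ADME assay on microsomes from liver (Homo sapiens) for metabolic stability (on this read-out higher numbers stand for fast clearance and lower numbers for slow clearance), for the measured compounds:
- compound 1 `Fc1ccccc1Cc1nc(-c2nc(Cc3ccccc3)n[nH]2)n2ccccc12` gives "not determined" (no result reported) with no number to use
- compound 2 `Fc1ccccc1Cc1nc(-c2nc(C(F)(F)F)n[nH]2)n2ccccc12` gives 72 mL.min-1.g-1 as a number
- compound 3 `FC(F)(F)c1n[nH]c(-c2nc(Cc3cncnc3)c3ccccn23)n1` gives < 7 mL.min-1.g-1 which is a limit of the assay and not a number

For the measured compounds named here, compound 2 holds the only exact number in the set, so it is the reference for the next step. Compound 4 `Fc1ccccc1Cc1nc(-c2ncn[nH]2)n2ccccc12` differs from it by hydrogen in place of trifluoromethyl on an aromatic carbon.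

Going by the values given here, the one measured step is an at least 10-fold lower number from compound 2 to compound 3 (1.01 log units; beyond the scatter) with pyrimidin-5-yl in place of 2-fluorophenyl on a saturated chain carbon bound to an aromatic carbon. That large step lies elsewhere in the structure, so it shows only that the read-out can move widely in this series. Compound 1 offers no number for comparison. Among the compounds with values here, no measured step touches the carbon that changes in compound 4, so the direction is a weakly supported judgement. The estimated change is a 2.1-fold lower number from compound 2 to compound 4 (0.31 log units; beyond the scatter) as an expected move towards slower clearance, smaller than the measured one. In this assay the estimate for compound 4 is 35 mL.min-1.g-1 with a range from 12 mL.min-1.g-1 to 85 mL.min-1.g-1 expected for the measurement.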

Compound 4, intrinsic clearance in microsomes: 175 mL.min-1.g-1
Estimate against measurement, compound 4: 5.0-fold (0.70 log units) below; measured number above the stated range.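

For the compounds shown here, the step of a 2.4-fold higher number from compound 2 to compound 4 (0.39 log units; beyond the scatter) in this assay is the first reading at this carbon, and it shows that this position moves the read-out too, not only the far end of the molecule. With 2-fluorophenyl held constant, hydrogen gives faster clearance than trifluoromethyl on this carbon of the five-membered aromatic ring, so here the four heavy atoms of trifluoromethyl go with the lower number. Nothing measured here explains the rise.

From the compounds shown here alone, only trifluoromethyl and hydrogen can be compared at this carbon, so it stays open whether a small group such as methyl, or an amine, would sit nearer compound 2 or compound 4. Going by these compounds, it also stays open whether the same direction would hold with pyrimidin-5-yl in place of 2-fluorophenyl.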